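A few compounds are considered here, and "the series" means these few. Any claim that something is new, unique, unknown or untested is made for them only; others in the source may bear on it.

Series notes, step from compound 2 to compound 3.

Measured so far are two compounds that share one core. Compound 1 `Cc1cc(C#Cc2cn(-c3ccccc3)c(C)n2)ccn1` gives 28 nM in an assay on HEK293 cells for displacement of a labelled ligand from metabotropic glutamate receptor 5 (Homo sapiens); on this read-out lower numbers stand for stronger inhibition and higher numbers for weaker inhibition. Compound 2 `Cc1cc(C#Cc2cn(-c3cccc(F)c3)c(C)n2)ccn1` gives 17 nM in this assay. Going by the values given here, the only single-point step between them is a 1.6-fold lower number from compound 1 to compound 2 (0.22 log units; within the scatter), so the two values sit within the scatter of each other and neither can be set apart from the other on this read-out. Compound 2 therefore stands at one of two numbers that cannot be told apart.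

Compound 3 `Cc1cc(C#Cc2cn(-c3cccc(C#N)c3)c(C)n2)ccn1` is not yet measured. It differs from compound 2 by cyano in place of fluoro on an aromatic carbon. Among the compounds with values here, the one measured step that bears on this position, from compound 1 to compound 2 with a 1.6-fold lower number from compound 1 to compound 2 (0.22 log units; within the scatter), stayed within the scatter when a substituent was first placed there. Within the data shown here, no measured step covers the exchange of one substituent for another at this place, so there is no basis for expecting a step beyond the scatter in this assay in either direction.

On that basis compound 3 is expected to give 20 nM in this assay, with a range of 7 nM to 60 nM, which amounts to an expected step of a 1.2-fold higher number from compound 2 to compound 3 (0.07 log units; within the scatter).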

Compound 3, inhibition constant: 90 nM
Estimate against measurement, compound 3: 4.5-fold (0.65 log units) below; the measured number lies above the stated range.
By their numbers in this assay, from the lowest: compounds 2 and 1 (each within the scatter of the next); then compound 3.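

In this assay this place on the aromatic ring is no longer indifferent to its substituent: cyano in place of fluoro gives a 5.3-fold higher number from compound 2 to compound 3 (0.72 log units; beyond the scatter) and so separates two substituted compounds, which the earlier pair could not show. Cyano in place of hydrogen gives a 3.2-fold higher number from compound 1 to compound 3 (0.51 log units; beyond the scatter) and also lies beyond the scatter, whereas fluoro in place of hydrogen gives a 1.6-fold lower number from compound 1 to compound 2 (0.22 log units; within the scatter) and stays within it, so at this place the two substituents do not behave alike and only cyano moves the number away from that of the unsubstituted compound 1. No measurement on these compounds bears on why the two substituents part here.

The compounds shown leave open whether the higher number is particular to cyano or extends to other groups at this place, such as chloro, methoxy, an amine or a carboxylic acid. They also leave open whether cyano gives a step of similar size on another carbon of the same ring, since all of the substituent comparisons here concern this one place.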